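The source may hold more compounds than are shown below. What is called first, only, known or untested is meant among the compounds shown, and "the series" means these compounds.

Measured so far in a functional assay on A-375 cells (Homo sapiens) for inhibition, read by sulforhodamine B assay, with a stated time of 48 h; a higher number here means a weaker inhibitor of growth, a lower number a stronger inhibitor of growth:
Compound 1 `COC(=O)c1sc2cc(-c3cnn(C)c3)cnc2c1N` gives > 150000 nM, which is a limit of the assay.
Compound 2 `COC(=O)c1sc2cc(-c3ccc(C#N)cc3)cnc2c1N` gives > 75000 nM, which is also a limit of the assay.

Compound 1 therefore stands at a limit only, as shown by the limit of > 150000 nM in this assay, at which 1 of the 2 values shown sits; its position against compound 2 cannot be set, since that value sits at a limit too, as shown by the limit of > 75000 nM in this assay, at which 1 of the 2 values shown sits.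

Compound 3 `COC(=O)c1sc2cc(-c3cccc(N)c3)cnc2c1N` has not yet been measured. It differs from compound 1 by 3-aminophenyl in place of 1-methyl-1H-pyrazol-4-yl on an aromatic carbon. Among the compounds with values here, no measured step exists to gauge such a change in this assay. The step from compound 1 to compound 3 is expected to stay within the scatter, an at least 1.2-fold lower number from compound 1 to compound 3 (0.09 log units; that floor lies within the scatter). Compound 3 is expected to give about 120000 nM, in the range 30000 nM to 300000 nM, most likely again reported only as a limit.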

Compound 3, concentration for 50% growth inhibition: > 150000 nM
Compound 3 gave a limit, no number; the forecaster's own chance of this, stated with the estimate: 70%; at least 1.2-fold (0.09 log units) between middle value and limit.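

Compound 1 and compound 3 are both reported only as limits, and the step between them cannot be read. The compounds shown leave open whether any group on this aromatic carbon gives a measurable number rather than a limit.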